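The source may report more compounds than this note shows. Statements on the series, on what has been measured and on what is new or still open speak of the compounds shown alone.

Measured so far in an ADME assay on L6 cells (Rattus norvegicus) for cytotoxicity, read by resazurin assay, with a stated time of 70 h; on this read-out lower numbers stand for stronger inhibition and higher numbers for weaker inhibition:
compound 1 `N=C(N)c1ccc2oc(-c3cccc(OCCCCCOc4ccccc4)c3)cc2c1` gives 3000 nM
compound 2 `N=C(N)c1ccc2oc(-c3cccc(OCCCCCCOc4ccccc4)c3)cc2c1` gives 3100 nM
compound 3 `N=C(N)c1ccc2cc(-c3ccc(OCCCCCOc4ccccc4)cc3)oc2c1` gives 9000 nM

Compound 1 and compound 2 share one core and differ at a single place: phenoxymethyl in place of phenoxy on a saturated chain carbon, five bonds along the chain from an oxygen on an aromatic ring. The step between them reads a 1.0-fold higher number from compound 1 to compound 2 (0.01 log units; within the scatter), so on this read-out the two lie together. Compound 3 carries the other core; compound 3 and compound 1 hold the same atoms joined differently, and the difference between the two cores is not broken down here. Compound 3 stands highest of the three numbers, with the gap to compound 2 and the gap to compound 1 both beyond the scatter.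

Compound 4 `N=C(N)c1ccc2cc(-c3ccc(OCCCCCCOc4ccccc4)cc3)oc2c1` has not yet been measured in this assay. It stands to compound 3 as compound 2 stands to compound 1: phenoxymethyl in place of phenoxy on a saturated chain carbon, five bonds along the chain from an oxygen on an aromatic ring. Within the data shown here, the place is described in the same words for both pairs, so this is the same change, and its only precedent is the pair compound 1 to compound 2. The expected step, on that single precedent, is a 1.0-fold higher number from compound 3 to compound 4 (0.01 log units; within the scatter). The number for compound 4 is expected to stay close to that of compound 3 because the earlier step of a 1.0-fold higher number from compound 1 to compound 2 (0.01 log units; within the scatter) lay within the scatter. Whether the change behaves alike on the other core rests on one pair only. Compound 4 is therefore estimated at 9300 nM, with a range expected from 4500 nM to 19000 nM.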

Compound 4, half-maximal inhibitory concentration: 8000 nM
Compound 4: the middle estimate sits 1.2-fold (0.07 log units) above what was measured, within the range that was stated.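

In this assay, phenoxymethyl in place of phenoxy on the second core gives a 1.1-fold lower number from compound 3 to compound 4 (0.05 log units; within the scatter), so the two numbers lie together on this read-out. Set beside the first core, the change shows no difference that can be told from the scatter: the same change on two cores in this assay, a 1.0-fold higher number (0.01 log units; within the scatter) from compound 1 to compound 2 and a 1.1-fold lower number (0.05 log units; within the scatter) from compound 3 to compound 4, 1.2-fold (0.07 log units) apart, within the scatter of two such steps This supports carrying this one change between these two cores in this assay, but it rests on two pairs at a single place, and it does not show that the change would behave alike on any further core or on any other read-out, nor does it account for the difference between the two cores themselves.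

Still open, as far as these compounds go, is whether the numbers stay together when the chain is extended further at the same place, with 2-phenoxyethyl or 3-phenoxypropyl on either core, since a flat step across one such extension does not fix the trend over a longer range. Also open, from the compounds shown here alone, is what happens when the chain ends in something other than an aromatic ring, such as an amine or a carboxylic acid in place of the phenoxy group, or when that ring carries a fluorine or a methoxy group.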